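The source may hold more compounds than are shown below. What is called first, only, known or untested is meant among the compounds shown, and "the series" means these compounds.

Measured so far:
compound 1, `C[C@H](NC(=O)C(=O)NCC1CCCCC1)C(=O)N[C@@H](CC(=O)O)C(=O)COc1c(F)c(F)cc(F)c1F`: 19 nM
compound 2, `C[C@H](NC(=O)C(=O)Nc1cccnc1N(C)C)C(=O)N[C@@H](CC(=O)O)C(=O)COc1c(F)c(F)cc(F)c1F`: 27 nM
compound 3, `Cc1ccccc1CNC(=O)C(=O)N[C@@H](C)C(=O)N[C@@H](CC(=O)O)C(=O)COc1c(F)c(F)cc(F)c1F`: 52 nM

These three share one core and differ only in the group carried on an amide-type nitrogen. In a functional assay on Jurkat cells (Homo sapiens) (on this read-out lower numbers stand for stronger inhibition and higher numbers for weaker inhibition), compound 2 gives 27 nM, the second highest of the three numbers; its nearest neighbour is compound 1 with 19 nM and its furthest is compound 3 with 52 nM, and both gaps fall within the usual scatter. Compound 4, `C[C@H](NC(=O)C(=O)NCc1cc(Cl)cc(Cl)c1)C(=O)N[C@@H](CC(=O)O)C(=O)COc1c(F)c(F)cc(F)c1F`, has not yet been measured. It differs from compound 2 in one place: 3,5-dichlorobenzyl in place of 2-(dimethylamino)pyridin-3-yl on an amide-type nitrogen. Among the measured compounds shown here, two measured steps touch this same position: the step of a 1.4-fold higher number from compound 1 to compound 2 (0.15 log units; within the scatter) and the step of a 1.9-fold higher number from compound 2 to compound 3 (0.28 log units; within the scatter), both small, while the step of a 2.7-fold higher number from compound 1 to compound 3 (0.44 log units; beyond the scatter) is modest. Swapping this group thus seems to matter little among these compounds. Because compound 3, which also carries a benzyl-type group, gives 52 nM, compound 4 is expected to land near 35 nM, with a range from 12 nM to 100 nM. This amounts to an expected step of a 1.3-fold higher number from compound 2 to compound 4 (0.11 log units; within the scatter).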

Compound 4, half-maximal inhibitory concentration: 23 nM
The estimate for compound 4 lay 1.5-fold (0.18 log units) above the measured number; measured number inside the range.
By their numbers in this assay, from the lowest: compounds 1, 4, 2 and 3 (each within the scatter of the next, the first and the last beyond it).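

In this assay the change gives a 1.2-fold lower number from compound 2 to compound 4 (0.07 log units; within the scatter), so on this amide-type nitrogen a group with 2 hydrogen-bond acceptors can give way to one with 0 without a shift that stands out from the scatter. The benzyl-type groups do not all behave alike, however: 3,5-dichlorobenzyl in place of 2-methylbenzyl gives a 2.3-fold lower number from compound 3 to compound 4 (0.35 log units; beyond the scatter), which shows that the substituents on the ring can matter modestly here. An aromatic ring can also match a saturated one, as 3,5-dichlorobenzyl in place of cyclohexylmethyl gives only a 1.2-fold higher number from compound 1 to compound 4 (0.08 log units; within the scatter), which leaves compound 3 as the exception to the otherwise flat picture.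

From the compounds shown here alone, whether a group carrying an amine or a carboxylic acid on this nitrogen would stay in the same range remains open. Nothing available explains why these groups give such similar numbers.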